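Acetylation of a free hydroxyl on two related cores

The source may report more compounds than this note shows. Statements on the series, on what has been measured and on what is new or still open speak of the compounds shown alone.

Compound 1 `CCC(=O)O[C@@H](/C(C)=C/[C@@H](C)c1oc(CC)c(C)c(=O)c1C)[C@H](C)[C@@H](OC(=O)CC(C)C)[C@@H](C)c1oc([C@@H](C)[C@@H](O)CC)c(C)c(=O)c1C` gives 12000 nM in a functional assay on A549 cells (Homo sapiens) for inhibition, read by MTT assay, with a stated time of 72 h; on this read-out lower numbers stand for stronger inhibition and higher numbers for weaker inhibition. Compound 3 `CCC(=O)O[C@@H](/C(C)=C/[C@@H](C)c1oc(CC)c(C)c(=O)c1C)[C@H](C)[C@@H](OC(=O)CC(C)C)[C@@H](C)c1oc([C@@H](C)[C@H](CC)OC(C)=O)c(C)c(=O)c1C` carries one added group, (acetyl in place of hydrogen on an oxygen on a saturated carbon), and in this assay compound 3 gives 3000 nM; the step is a 4.0-fold lower number from compound 1 to compound 3 (0.60 log units; beyond the scatter). Compound 2 `CCc1oc([C@H](C)/C=C(\C)[C@H](O)[C@H](C)[C@@H](OC(=O)CC(C)C)[C@@H](C)c2oc([C@@H](C)[C@@H](O)CC)c(C)c(=O)c2C)c(C)c(=O)c1C` differs from compound 1 in its core by hydrogen in place of propanoyl on an oxygen on a saturated carbon. In this assay compound 2 reaches only the limit > 100000 nM. The step of an at least 8.3-fold higher number from compound 1 to compound 2 (0.92 log units; beyond the scatter) is therefore a bound that rests on (the limit of > 100000 nM in this assay, at which 1 of the 3 values shown sits). Compound 4 `CCc1oc([C@H](C)/C=C(\C)[C@H](OC(C)=O)[C@H](C)[C@@H](OC(=O)CC(C)C)[C@@H](C)c2oc([C@@H](C)[C@@H](O)CC)c(C)c(=O)c2C)c(C)c(=O)c1C` is not yet measured; it differs from compound 2 by acetyl in place of hydrogen on an oxygen on a saturated carbon, the same change as from compound 1 to compound 3, at a place described in the same words. For compound 4 the expected step is an at least 2.0-fold lower number from compound 2 to compound 4 (0.30 log units; that floor lies within the scatter), resting on a 4.0-fold lower number from compound 1 to compound 3 (0.60 log units; beyond the scatter) applied to a starting point that is itself only a limit. Compound 4 is estimated at 50000 nM in this assay, between 12000 nM and 250000 nM, with a real chance that only a limit is reported again.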

Compound 4, half-maximal inhibitory concentration: 15000 nM
The estimate for compound 4 lay 3.3-fold (0.52 log units) above the measured number; the range from low to high includes it.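

Acetyl in place of hydrogen on an oxygen on a saturated carbon gives a lower number on both cores in this assay: the same change on two cores in this assay, a 4.0-fold lower number (0.60 log units; beyond the scatter) from compound 1 to compound 3 and an at least 6.6-fold lower number (0.82 log units; beyond the scatter) from compound 2 to compound 4; the limit leaves it open whether they differ

On these data alone, the value of compound 2, > 100000 nM, is a limit, so the step, an at least 6.6-fold lower number from compound 2 to compound 4 (0.82 log units; beyond the scatter), is only a bound and the true size of the change on that core stays unknown. Acetyl and propanoyl on that oxygen read alike, with a 1.3-fold higher number from compound 1 to compound 4 (0.10 log units; within the scatter), and two cores show a shared direction, not a rule for the whole series.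

Still open, as far as these compounds go, is whether a longer acyl chain such as butanoyl, or a benzoyl group, on that oxygen would read like acetyl and propanoyl. Also open, from the compounds shown here alone, is how an acyl group carrying an amine or a carboxylic acid would read.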